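This account rests on a few compounds, and the source may have more. Where it says the series, first, only, none or still open, it means among the compounds named here.

The shared core, seen in compound 1 `CCCCCCCCc1ccc(OCC(=O)Cn2nnc(-c3cccc(S(=O)(=O)N(C)C)c3)n2)cc1`, carries an octyl chain at one end and a five-membered ring with four nitrogen atoms at the other, and the group attached to that ring is what varies here. In an assay on microsomes from brain for inhibition of Fatty-acid amide hydrolase 1 (Rattus norvegicus), read by fluorescence and HPLC, with a stated time of 60 min (a higher number here means a weaker inhibitor, a lower number a stronger inhibitor), compound 1 gives 420 nM. Compound 2 `CCCCCCCCc1ccc(OCC(=O)Cn2nnc(-c3cccnc3)n2)cc1` gives 23 nM, and compound 3 `CCCCCCCCc1ccc(OCC(=O)Cn2nnc(-c3cccs3)n2)cc1` gives 32 nM. Both smaller aromatic groups sit far from the sulfonamide-bearing phenyl: an 18-fold lower number from compound 1 to compound 2 (1.26 log units; beyond the scatter) and a 13-fold lower number from compound 1 to compound 3 (1.12 log units; beyond the scatter) are large steps, whereas a 1.4-fold higher number from compound 2 to compound 3 (0.14 log units; within the scatter) is within the scatter, so compound 3 stands with compound 2 among the stronger inhibitors, second of the three numbers, and far from compound 1.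

Compound 4 `CCCCCCCCc1ccc(OCC(=O)Cn2nnc(Cc3ccccc3)n2)cc1` is the next step from compound 3: benzyl in place of thiophen-2-yl on an aromatic carbon. For the measured compounds named here, no measured step tells what happens when a one-carbon link is inserted between the core and a plain six-membered ring; the steps from compound 1 show only that a large polar substituent on the ring costs a great deal of potency, which this change does not introduce. The expectation is therefore a modest weakening, a 2.5-fold higher number from compound 3 to compound 4 (0.40 log units; beyond the scatter), and compound 4 is estimated at 80 nM in this assay, within a range from 25 nM to 300 nM.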

Compound 4, half-maximal inhibitory concentration: 66 nM
Beside the measured number, compound 4's estimate is 1.2-fold (0.08 log units) above it, within the range that was stated.
By their numbers in this assay, from the lowest: compounds 2 and 3 (each within the scatter of the next); then compound 4; then compound 1.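

For the compounds shown here, on the aromatic carbon of the five-membered ring with four nitrogen atoms, the earlier compounds held their rings directly, and benzyl now shows that a carbon-only ring set one carbon away still gives a usable inhibitor in this assay at a price: a 2.1-fold higher number from compound 3 to compound 4 (0.31 log units; beyond the scatter) and a 2.9-fold higher number from compound 2 to compound 4 (0.46 log units; beyond the scatter) are both modest steps, yet both lie beyond the scatter. Compound 4 still keeps a good part of the advantage over the 3-(dimethylsulfamoyl)phenyl group, with a 6.4-fold lower number from compound 1 to compound 4 (0.80 log units; beyond the scatter) also modest, so it sits on a level of its own, apart from the two earlier groupings. The change alters the link, the ring size and the hetero atom all at once, and nothing available here separates these or explains the loss.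

The compounds shown leave open whether phenethyl, with its longer chain, would move the number further in the same direction, and whether pyridin-3-ylmethyl would recover what benzyl gives up. They also leave open how this position responds to a small group with no ring at all, such as methyl, or to a carboxylic acid or an amine.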